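Changing the Amide-Linked Ring in a Histone Deacetylase 8 Series

A few compounds are considered here, and "the series" means these few. Any claim that something is new, unique, unknown or untested is made for them only; others in the source may bear on it.

Compound 1, `O=C(COc1ccc2cc(/C=C3/SC(=O)NC3=O)ccc2c1)Nc1ccc(F)cc1F`: > 50000 nM
Compound 2, `O=C(COc1ccc2cc(/C=C3/SC(=O)NC3=O)ccc2c1)Nc1ccc([N+](=O)[O-])cc1`: 4000 nM
Compound 3, `Cc1cccc2sc(NC(=O)COc3ccc4cc(/C=C5/SC(=O)NC5=O)ccc4c3)nc12`: 5800 nM

In an assay on isolated protein for inhibition of histone deacetylase 8 (Homo sapiens), with a stated time of 1 h (on this read-out lower numbers stand for stronger inhibition and higher numbers for weaker inhibition), compound 1 stands at a limit rather than a number: the limit of > 50000 nM in this assay, at which 1 of the 3 values shown sits. Compound 2 and compound 3 both return numbers, and their difference from each other, a 1.5-fold higher number from compound 2 to compound 3 (0.16 log units; within the scatter), is within the scatter.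

Compound 4, `O=C(COc1ccc2cc(/C=C3/SC(=O)NC3=O)ccc2c1)Nc1cccc(Cl)c1`, is the next step from compound 1. The change is 3-chlorophenyl in place of 2,4-difluorophenyl on an amide-type nitrogen. Two measured steps start from the same 2,4-difluorophenyl group on the amide-type nitrogen: an at least 12-fold lower number from compound 1 to compound 2 (1.09 log units; beyond the scatter) and an at least 8.6-fold lower number from compound 1 to compound 3 (0.93 log units; beyond the scatter). Both replace that group and both lower the number well beyond the scatter. The groups that enter there, 4-nitrophenyl and 4-methyl-1,3-benzothiazol-2-yl, are not 3-chlorophenyl, so they show only that leaving the 2,4-difluorophenyl group has so far been favourable, not how far a single chlorine on the ring will go.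

Compound 4 is therefore expected to give a lower number than the limit of compound 1, by a step of an at least 2.5-fold lower number from compound 1 to compound 4 (0.39 log units; beyond the scatter), with a real chance that it again reaches only a limit. The estimate for compound 4 in this assay is 20000 nM, with a range from 4000 nM to 100000 nM.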

Compound 4, half-maximal inhibitory concentration: > 50000 nM
Compound 4 ended at the assay's limit (the forecaster's own chance of this, stated with the estimate: 40%); at least 2.5-fold (0.39 log units) between middle value and limit.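

Compound 1 and compound 4 both stand at a limit of the assay rather than at a number, so the step between them cannot be read: the limit of > 50000 nM in this assay, at which 2 of the 4 values shown sit.

What is new is that leaving the 2,4-difluorophenyl group does not by itself bring a measurable value in this assay, as the 3-chlorophenyl group shows with an at least 12-fold higher number from compound 2 to compound 4 (1.09 log units; beyond the scatter) and with an at least 8.6-fold higher number from compound 3 to compound 4 (0.93 log units; beyond the scatter). On this amide-type nitrogen the outcome therefore depends on which ring enters, and among the four compounds shown, the two phenyl rings carrying halogens stay at the limit, while the 4-nitrophenyl and 4-methyl-1,3-benzothiazol-2-yl groups return numbers.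

Compound 2 and compound 4 differ both in the group on the phenyl ring and in where it sits, so the compounds shown leave open which of these two differences matters. They also leave open whether a phenyl ring with no added group, or one carrying an amine or a carboxylic acid, would return a number or stay at the limit.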